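The compounds below may be only part of what the source reports. "The series", "measured", "known", "first", "only" and "open" are said of these compounds alone.

Measured so far:
- Compound 1, `C=CCn1ncc2c(C)nc(CC)n2c1=O`: in a functional assay for inhibition, with Homo sapiens as the target (on this read-out higher numbers stand for weaker inhibition and lower numbers for stronger inhibition), compound 1 gives > 48000 nM, which is a limit of the assay.
- Compound 2, `C=CCn1ncc2c(C)nc(C)n2c1=O`: in this assay compound 2 gives 73000 nM.
- Compound 3, `CCc1ncn2c(S)nncc12`: in this assay compound 3 gives > 48000 nM, which is again a limit.

The change from compound 1 to compound 2 is hydrogen in place of methyl on a saturated chain carbon bound to an aromatic carbon. The step it makes, a step that the limit leaves unreadable from compound 1 to compound 2, has no readable size because the limit of > 48000 nM in this assay, at which 2 of the 3 values shown sit, applies to compound 1. Both values are weak, and nothing beyond that can be taken from the pair.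

Compound 4, `Cc1ncn2c(S)nncc12`, has not yet been measured. Its difference from compound 3 is hydrogen in place of methyl on a saturated chain carbon bound to an aromatic carbon, the same change as from compound 1 to compound 2, at the same place. The difference between the core of compound 3 and the core of compound 1 is not broken down here.

Among the compounds with values here, what is known of compound 3 is only a limit, and the one measured instance of this change is itself unreadable, so no directional expectation can be drawn from the series. In this assay compound 4 is expected to remain weak and most likely to come back as a limit once more. The expected step is a step that the limit leaves unreadable from compound 3 to compound 4. For compound 4 the estimate is 70000 nM, with a range from 30000 nM to 200000 nM.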

Compound 4, half-maximal inhibitory concentration: > 48000 nM
Compound 4: only a limit was reported; the forecaster's own chance of this, stated with the estimate: 85%; the middle value does not contradict the limit.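

Compound 4 returns a limit of the assay, as compound 3 does, so no new step can be read between the two: the limit of > 48000 nM in this assay, at which 3 of the 4 values shown sit.

The compounds shown leave open whether the change from ethyl to methyl shifts inhibition in either direction, on the core of compound 1 or on the core of compound 3.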